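The source may hold more compounds than are shown below. What is called first, only, known or untested is meant among the compounds shown, and "the series" means these compounds.

Three compounds share one core and differ only in the ring hanging from it. Compound 1 `COc1ccc(-c2cc(-c3ccccc3-c3ccccc3)n[nH]2)cc1` gives 670 nM in a functional assay on OVCAR cells (Homo sapiens) for inhibition, read by MTT assay, with a stated time of 48 h; on this read-out lower numbers stand for stronger inhibition of growth and higher numbers for weaker inhibition of growth. Compound 2 `FC(F)(F)c1ccc(-c2cc(-c3ccccc3-c3ccccc3)n[nH]2)cc1` gives 2750 nM in this assay, a change of a 4.1-fold higher number from compound 1 to compound 2 (0.61 log units; beyond the scatter), brought about by trifluoromethyl in place of methoxy on an aromatic carbon. Compound 3 `COc1cccc(-c2cc(-c3ccccc3-c3ccccc3)n[nH]2)c1` gives 5800 nM in this assay, the highest of the three numbers, with a change of an 8.7-fold higher number from compound 1 to compound 3 (0.94 log units; beyond the scatter) from moving the methoxy group; the values of compound 2 and compound 3 lie closer together but still apart.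

Compound 4 `Oc1ccc(-c2cc(-c3ccccc3-c3ccccc3)n[nH]2)cc1` carries 4-hydroxyphenyl in place of 3-methoxyphenyl on an aromatic carbon. The step from compound 1 to compound 3 is the one that bears on this change, since it also moves the substituent from the position found in compound 4 to that found in compound 3; reversing it points toward a lower number. Among the measured compounds shown here, no measured pair shows what hydroxy in place of methoxy does, so the size is uncertain. In this assay compound 4 is therefore expected to give 1000 nM, within a range of 250 nM to 4000 nM. The expected change in this assay is a 5.8-fold lower number from compound 3 to compound 4 (0.76 log units; beyond the scatter).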

Compound 4, concentration for 50% growth inhibition: 6200 nM
The estimate for compound 4 lay 6.2-fold (0.79 log units) below the measured number; the whole stated range lies below it.
By their numbers in this assay, from the lowest: compound 1; then compound 2; then compounds 3 and 4 (each within the scatter of the next).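

Removing only the methyl from the oxygen of compound 1 raises the number markedly (a step of a 9.3-fold higher number from compound 1 to compound 4 (0.97 log units; beyond the scatter)) in this assay, so among these compounds, an oxygen on the ring in 4-hydroxyphenyl does not match the result for the methoxy group of compound 1. The hydroxy compound also gives a higher number than its trifluoromethyl partner (a step of a 2.3-fold higher number from compound 2 to compound 4 (0.35 log units; beyond the scatter)), whereas it cannot be told apart from the 3-methoxyphenyl compound (a step of a 1.1-fold higher number from compound 3 to compound 4 (0.03 log units; within the scatter)). No measurement shown here explains why the methyl group matters.

Going by these compounds, it remains open what an amine or a carboxylic acid would do in place of the methoxy of compound 1. On these data alone, it is also open whether ethoxy, with its longer chain on the same oxygen, would keep the number low or raise it.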